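Amide nitrogen substituent: aryl to isopropyl

This account rests on a few compounds, and the source may have more. Where it says the series, first, only, none or still open, it means among the compounds named here.

Compound 2 `Cc1ccccc1NC(=O)c1ccc(Nc2ncc(C)c(-c3ccc(OC(F)(F)F)cc3)n2)cc1` gives 1 nM in an assay on NIH3T3 cells for inhibition of Sonic hedgehog protein (Mus musculus), read by a luciferase reporter, with a stated time of 48 h; on this read-out higher numbers stand for weaker inhibition and lower numbers for stronger inhibition; compound 1 `Cc1cnc(Nc2ccc(C(=O)Nc3c(C)cccc3C)cc2)nc1-c1ccc(OC(F)(F)F)cc1` gives 1.3 nM, and the two sit within the scatter of each other. Within the data shown here, the only measured step, a 1.3-fold lower number from compound 1 to compound 2 (0.11 log units; within the scatter), touches an aromatic methyl and tells nothing about the amide substituent. Compound 3 `Cc1cnc(Nc2ccc(C(=O)NC(C)C)cc2)nc1-c1ccc(OC(F)(F)F)cc1` carries isopropyl in place of 2-methylphenyl on an amide-type nitrogen. Among the measured compounds shown here, no measured step bears on this change, so the expectation rests on the change alone: the number is expected to rise, with the expected step being a 12-fold higher number from compound 2 to compound 3 (1.08 log units; beyond the scatter). Compound 3 is estimated at 12 nM, with a range from 2 nM to 80 nM.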

Compound 3, half-maximal inhibitory concentration: 73.1 nM
Beside the measured number, compound 3's estimate is 6.1-fold (0.78 log units) below it, and the stated range covers the measured number.
By their numbers in this assay, from the lowest: compounds 2 and 1 (each within the scatter of the next); then compound 3.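

Here the series first shows a change that moves the number beyond the scatter: isopropyl in place of 2-methylphenyl on the amide-type nitrogen gives a 73-fold higher number from compound 2 to compound 3 (1.86 log units; beyond the scatter) and isopropyl in place of 2,6-dimethylphenyl gives a 56-fold higher number from compound 1 to compound 3 (1.75 log units; beyond the scatter) in the second comparison. The step to isopropyl is large from either aryl group, whereas the earlier aromatic methyl change stayed within the scatter. Nothing given here accounts for this loss.

From the compounds shown here alone, whether the loss follows the aromatic ring or the carbon count stays open; cyclohexyl on this nitrogen would separate the two. Going by these compounds, how a benzyl group or a chain ending in an amine would read here is also open.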